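This account rests on a few compounds, and the source may have more. Where it says the series, first, only, none or still open, it means among the compounds named here.

In a functional assay on A549 cells (Homo sapiens) for cytotoxicity, read by MTT assay, with a stated time of 72 h (a lower number here means a stronger inhibitor, a higher number a weaker inhibitor), three compounds with a shared core have been measured. Compound 1 `COc1cc2ncnc(Nc3ccc(F)c(Cl)c3)c2cc1NC(=O)N/N=C/c1cccc(Br)c1` gives 28100 nM, compound 2 `COc1cc2ncnc(Nc3ccc(F)c(Cl)c3)c2cc1NC(=O)N/N=C/c1ccc(C#N)cc1` gives 32200 nM, and compound 3 `COc1cc2ncnc(Nc3ccc(F)c(Cl)c3)c2cc1NC(=O)N/N=C/c1ccc(F)cc1Cl` gives 28200 nM, so compound 3 stands level with the other two. Compound 4 `COc1cc2ncnc(Nc3ccc(F)c(Cl)c3)c2cc1NC(=O)N/N=C/c1ccc(OC)c(OC)c1OC` differs from compound 3 in one place: 2,3,4-trimethoxyphenyl in place of 2-chloro-4-fluorophenyl on a carbon with a double bond to nitrogen. Within the data shown here, three measured steps bear on this change at the same place: a 1.0-fold higher number from compound 1 to compound 3 (0.00 log units; within the scatter), a 1.1-fold lower number from compound 2 to compound 3 (0.06 log units; within the scatter) and a 1.1-fold higher number from compound 1 to compound 2 (0.06 log units; within the scatter). All three lie within the scatter, so no step beyond the scatter is expected in this assay. Among the measured compounds shown here, no measured compound carries 2,3,4-trimethoxyphenyl, so the range stays wide. The estimated change is a 1.0-fold lower number from compound 3 to compound 4 (0.00 log units; within the scatter). Compound 4 is expected at 28000 nM, within a range of 12000 nM to 60000 nM.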

Compound 4, half-maximal inhibitory concentration: 32800 nM
Compound 4: middle estimate off by 1.2-fold (0.07 log units), on the low side; low and high end bracket the measured number.
By their numbers in this assay, from the lowest: compounds 1, 3, 2 and 4 (each within the scatter of the next).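

In this assay, 2,3,4-trimethoxyphenyl brings more heavy atoms and adds hydrogen-bond acceptors, yet every comparison stays within the scatter (a 1.2-fold higher number from compound 3 to compound 4 (0.07 log units; within the scatter)) (a 1.0-fold higher number from compound 2 to compound 4 (0.01 log units; within the scatter)) (a 1.2-fold higher number from compound 1 to compound 4 (0.07 log units; within the scatter)). Across these four compounds, then, methoxy-bearing, halogen-bearing and nitrile-bearing phenyl groups on this carbon give numbers that cannot be told apart. Nothing measured here offers a reason for this flat result. Still open, going by these compounds, is whether an amine or a carboxylic acid on this phenyl ring, or a saturated ring in its place, would move the number beyond the scatter.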